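Adding a sulfamoyl group to a weak anilide-type inhibitor

The source may report more compounds than this note shows. Statements on the series, on what has been measured and on what is new or still open speak of the compounds shown alone.

Of the compounds shown here, three that share one core have been tested in a functional assay on MIA PaCa-2 cells (Homo sapiens) for inhibition, read by MTT assay; a higher number here means a weaker inhibitor, a lower number a stronger inhibitor. Compound 1 `CCC(CO)Nc1ncc2cc(C(=O)N(C)C)n(C3CCCC3)c2n1` gives 31000 nM. Compound 2 `CN(C)C(=O)c1cc2cnc(Nc3ccccc3)nc2n1C1CCCC1` gives 54900 nM, the highest of the three numbers, while compound 3 `CN(C)C(=O)c1cc2cnc(Nc3cccnc3)nc2n1C1CCCC1` gives 26000 nM. The changes among them were small: a 1.8-fold higher number from compound 1 to compound 2 (0.25 log units; within the scatter), a 1.2-fold lower number from compound 1 to compound 3 (0.08 log units; within the scatter) and a 2.1-fold lower number from compound 2 to compound 3 (0.32 log units; beyond the scatter).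

Compound 4 `Cc1cc(C)nc(NS(=O)(=O)c2ccc(Nc3ncc4cc(C(=O)N(C)C)n(C5CCCC5)c4n3)cc2)n1` is built from compound 2 by one change: (4,6-dimethylpyrimidin-2-yl)sulfamoyl in place of hydrogen on an aromatic carbon. Among the measured compounds shown here, none of the measured steps touches this position; all three concern the group on the nitrogen on an aromatic ring, and each was small. There is therefore no measured guide to a step of this kind, and the measured steps suggest that changes around the core of compound 2 move this assay only modestly. A small step toward a lower number is expected, a 2.7-fold lower number from compound 2 to compound 4 (0.44 log units; beyond the scatter), with wide uncertainty. Compound 4 is estimated at 20000 nM, within a range from 5000 nM to 80000 nM.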

Compound 4, half-maximal inhibitory concentration: 8250 nM
Compound 4: middle estimate off by 2.4-fold (0.38 log units), on the high side; the measured number falls inside the stated range.
By their numbers in this assay, from the lowest: compound 4; then compounds 3, 1 and 2 (each within the scatter of the next, the first and the last beyond it).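

Placing (4,6-dimethylpyrimidin-2-yl)sulfamoyl on an aromatic carbon of the six-membered carbon ring, para to a large group, lowers the number in this assay, giving a 6.7-fold lower number from compound 2 to compound 4 (0.82 log units; beyond the scatter). This is the largest step among the compounds shown, so this position responds more than the swaps of the group on the nitrogen did, and a group of 12 heavy atoms can sit here without raising the number. No measurement shown explains this change.

Going by these compounds, the group entered as a single piece, so it remains open whether the sulfamoyl link or the dimethylpyrimidine ring matters more. A plain unsubstituted sulfamoyl, a carboxylic acid or a small amine at this same place would help separate the two.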